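The compounds below may be only part of what the source reports. "The series", "measured", "known", "first", "only" and "open" are said of these compounds alone.

In an assay on isolated protein for agonist activity at Bile acid receptor (Homo sapiens), read by TR-FRET, with a stated time of 3 h, in the absence of a further agent (a higher number here means that more compound is needed for the effect, a lower number that less compound is needed), compound 1 `O=C(O)c1ccc(NC(=O)c2ccc(Oc3ccccc3)cc2)cc1` gives > 10000 nM, which is a limit of the assay and not a number. Compound 2 `O=C(O)c1cccc(OCc2ccc(Oc3ccccc3)cc2)c1` likewise gives > 10000 nM, again a limit, namely (the limit of > 10000 nM in this assay, at which 2 of the 3 values shown sit). For the measured compounds named here, compound 3 `CCOc1cccc(C(=O)Nc2cccc(C(=O)O)c2)c1` gives 2350 nM, the only number among the three values shown. Compound 4 `CCCCOc1cccc(C(=O)Nc2cccc(C(=O)O)c2)c1` has not yet been measured in this assay; it differs from compound 3 by ethyl in place of hydrogen on a saturated chain carbon, two bonds along the chain from an oxygen on an aromatic ring, which read one bond further out is ethoxy to butoxy. Going by the values given here, no measured step covers this change, so the step from compound 3 to compound 4 is expected to be a 2.4-fold lower number from compound 3 to compound 4 (0.37 log units; beyond the scatter), toward less compound needed, and it may not exceed the usual scatter. Compound 4 is therefore expected to give 1000 nM, within a range from 300 nM to 4000 nM.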

Compound 4, half-maximal effective concentration: 3150 nM
For compound 4 the middle estimate is 3.2-fold (0.50 log units) below the measured one, within the range that was stated.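

In this assay, for the compounds shown here, the step from ethoxy to butoxy gives a 1.3-fold higher number from compound 3 to compound 4 (0.13 log units; within the scatter), the first reading of any change at this position. On a saturated chain carbon, two bonds along the chain from an oxygen on an aromatic ring, ethyl in place of hydrogen thus leaves the number within the scatter. Both ends of this step are numbers, unlike the other values shown, which are limits of the assay: the limit of > 10000 nM in this assay, at which 2 of the 4 values shown sit.

The compounds shown leave open how a longer chain such as hexyloxy, or an amine at the end of the chain, would read at this position.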